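Methoxy in Place of Chloro: A Small Step Expected

The source may report more compounds than this note shows. Statements on the series, on what has been measured and on what is new or still open speak of the compounds shown alone.

Of the compounds shown here, two have so far been measured in a functional assay on HCT-116 cells (Homo sapiens) for cytotoxicity, with a stated time of 3 days; on this read-out lower numbers stand for stronger inhibition and higher numbers for weaker inhibition. Compound 1 `Cn1c(I)nc2ccccc21` gives 17500 nM, and compound 2 `C#Cc1nc(C(=O)Nc2ccc(Cl)cc2)cs1` gives 15900 nM; these two values lie within the scatter of each other, so compound 2 holds the lower of two numbers without standing apart. Compound 3 `C#Cc1nc(C(=O)Nc2ccc(OC)cc2)cs1` differs from compound 2 in one place: methoxy in place of chloro on an aromatic carbon. Going by the values given here, no step between measured compounds is available, so no pattern guides the change; one expects a step of a 1.3-fold higher number from compound 2 to compound 3 (0.10 log units; within the scatter) in this assay, none beyond the scatter. Compound 3 is estimated to give 20000 nM, between 7000 nM and 55000 nM.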

Compound 3, half-maximal inhibitory concentration: 8390 nM
For compound 3 the middle estimate is 2.4-fold (0.38 log units) above the measured one; the measured number falls inside the stated range.
By their numbers in this assay, from the lowest: compounds 3, 2 and 1 (each within the scatter of the next, the first and the last beyond it).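

Methoxy in place of chloro on an aromatic carbon, para to a large group, gives a 1.9-fold lower number from compound 2 to compound 3 (0.28 log units; within the scatter) in this assay. Going by these compounds alone, this is the first step that can be read at this position, and it shows that this exchange does not carry the number beyond the scatter. Nothing at hand bears on a cause for this result. Going by these compounds, what remains open is whether an amine or a carboxylic acid at this position would move the number beyond the scatter. The same question stands for a longer chain in place of methoxy.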